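The source may report more compounds than this note shows. Statements on the series, on what has been measured and on what is new or still open speak of the compounds shown alone.

Three compounds share one core and are compared in an in vitro functional assay on HEK285-7 cells for antagonist activity at prostaglandin D2 receptor 2 (Homo sapiens), read by BRET and beta-arrestin recruitment; a higher number here means a larger maximal response, a lower number a smaller maximal response. Compound 1 `O=C(O)Cc1sc(COc2ccc(Cl)cc2)nc1-c1ccc(Cl)cc1` gives 50%. Compound 2 `O=C(O)Cc1sc(Cc2ccccc2)nc1-c1ccc(Cl)cc1` gives 50%. Compound 3 `O=C(O)Cc1sc(C(c2ccc(F)cc2)c2ccc(F)cc2)nc1-c1ccco1` gives 80%, the highest of the three; its gaps to compound 1 and to compound 2 lie beyond the scatter. For the measured compounds named here, the one measured step, no change at the digits printed from compound 1 to compound 2 (within the scatter), changed a group on a saturated chain carbon and left the maximal response flat within the scatter.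

Compound 4 `Cc1cc(-c2nc(C(c3ccc(F)cc3)c3ccc(F)cc3)sc2CC(=O)O)cnc1N` differs from compound 3 in a single place: 6-amino-5-methylpyridin-3-yl in place of furan-2-yl on an aromatic carbon. Going by the values given here, no measured step alters the group on this aromatic carbon, so the measured steps give no direct guidance; the single step seen elsewhere on the core was flat. The maximal response of compound 4 is therefore expected near that of compound 3, with a wide range: 70%, between 45% and 95%. The step expected from this change is a number 10 percentage points lower from compound 3 to compound 4 (within the scatter).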

Compound 4, largest response reached (reported as efficacy), in percent of the reference or control that the assay uses: 80%
Beside the measured number, compound 4's estimate is 10 percentage points below it, within the range that was stated.
By their numbers in this assay, from the lowest: compounds 1 and 2 (each within the scatter of the next); then compounds 3 and 4 (each within the scatter of the next).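

In this assay, for the compounds shown here, putting 6-amino-5-methylpyridin-3-yl in place of furan-2-yl on the aromatic carbon next to the ring nitrogen gives no change at the digits printed from compound 3 to compound 4 (within the scatter) and provides the first measured step at this position. The maximal response therefore tolerates a six-membered aromatic ring with 8 heavy atoms in place of a five-membered one with 5, even though the new group also brings a hydrogen-bond donor. Nothing available here explains why the response holds across this swap.

The amino and methyl groups arrive together, so their separate contributions stay unresolved. Unsubstituted pyridin-3-yl, or the same ring carrying only the amine or only the methyl group, would be needed to show whether either group matters at this position.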